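A few compounds are considered here, and "the series" means these few. Any claim that something is new, unique, unknown or untested is made for them only; others in the source may bear on it.

Measured compounds:
compound 1, `O=C(c1ccc(OCCCN2CCN(C(=O)[C@H]3CCCN3)CC2)cc1)C1CC1`: 53700 nM
compound 2, `CC(C)(C)OC[C@@H](N)C(=O)N1CCN(CCCOc2ccc(C(=O)C3CC3)cc2)CC1`: 45700 nM
compound 3, `CCC[C@@H](N)C(=O)N1CCN(CCCOc2ccc(C(=O)C3CC3)cc2)CC1`: 60300 nM

All three share one core and differ only in the group attached to the carbonyl carbon of the amide. In an assay for binding affinity to histamine H2 receptor (Homo sapiens) (on this read-out lower numbers stand for stronger inhibition and higher numbers for weaker inhibition), compound 3 gives the highest of the three numbers, yet this says little: the step of a 1.1-fold higher number from compound 1 to compound 3 (0.05 log units; within the scatter) and the step of a 1.3-fold higher number from compound 2 to compound 3 (0.12 log units; within the scatter) both stay within the scatter, as does a 1.2-fold lower number from compound 1 to compound 2 (0.07 log units; within the scatter). Compound 4, `N[C@H](CC1CCCCC1)C(=O)N1CCN(CCCOc2ccc(C(=O)C3CC3)cc2)CC1`, takes the next step at the same place, with cyclohexyl in place of ethyl on a saturated chain carbon, two bonds along the chain from an amine nitrogen and a carbonyl carbon. Within the data shown here, the one measured step that bears directly on it is a 1.3-fold higher number from compound 2 to compound 3 (0.12 log units; within the scatter), a swap of side groups at this very carbon that changed nothing beyond the scatter; the other two steps, which reshape the whole amine-bearing piece, also left the numbers flat. Nothing among these compounds suggests that a larger ring at this position should move the number, so the expected step of a 1.1-fold lower number from compound 3 to compound 4 (0.04 log units; within the scatter) is none beyond the scatter. The estimate for compound 4 is 55000 nM, with a range from 20000 nM to 150000 nM.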

Compound 4, inhibition constant: 20400 nM
Compound 4: the middle estimate sits 2.7-fold (0.43 log units) above what was measured, and the stated range covers the measured number.
By their numbers in this assay, from the lowest: compound 4; then compounds 2, 1 and 3 (each within the scatter of the next).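

In this assay, among these compounds, this saturated chain carbon responds beyond the scatter for the first time, with cyclohexyl in place of ethyl (a 3.0-fold lower number from compound 3 to compound 4 (0.47 log units; beyond the scatter)), and the change also holds against tert-butoxy at the same carbon (a 2.2-fold lower number from compound 2 to compound 4 (0.35 log units; beyond the scatter)) and against the pyrrolidin-2-yl group of compound 1 (a 2.6-fold lower number from compound 1 to compound 4 (0.42 log units; beyond the scatter)). All three steps are modest, but they show that the flat numbers among compounds 1, 2 and 3 did not mean this part of the molecule could never affect the read-out. Nothing measured here explains the shift.

The compounds shown leave open whether the ring itself matters or only the number of carbons, which a straight hexyl chain at this carbon would help separate. On these data alone, how a phenyl ring would compare with cyclohexyl also remains open.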